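Propyl to butyl: the next chain step in the series

The source may report more compounds than this note shows. Statements on the series, on what has been measured and on what is new or still open speak of the compounds shown alone.

In a functional assay on the whole organism with Scenedesmus acutus as the target (a higher number here means a weaker inhibitor, a lower number a stronger inhibitor), compound 1 `O=C(O)c1cc(N2C(=O)C3=C(CCCC3)C2=O)ccc1Cl` gives > 100000 nM, which is a limit of the assay and not a number. Compound 2 `CCOC(=O)c1cc(N2C(=O)C3=C(CCCC3)C2=O)ccc1Cl` gives 1380 nM. Compound 3 `CCCOC(=O)c1cc(N2C(=O)C3=C(CCCC3)C2=O)ccc1Cl` gives 1860 nM, which lies within the scatter of compound 2, so the two cannot be ordered.

Compound 4 `CCCCOC(=O)c1cc(N2C(=O)C3=C(CCCC3)C2=O)ccc1Cl` differs from compound 3 by methyl in place of hydrogen on a saturated chain carbon, three bonds along the chain from an oxygen next to a carbonyl group, which reads as propyl to butyl.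

Ethyl in place of hydrogen on an oxygen next to a carbonyl group gave an at least 72-fold lower number from compound 1 to compound 2 (1.86 log units; beyond the scatter), and propyl there gave an at least 53-fold lower number from compound 1 to compound 3 (1.73 log units; beyond the scatter). Those large steps are a different change. Within the data shown here, the closest precedent is the previous methyl addition on the chain, a 1.3-fold higher number from compound 2 to compound 3 (0.13 log units; within the scatter), so no step beyond the scatter is expected in this assay.

The expected step is a 1.1-fold higher number from compound 3 to compound 4 (0.03 log units; within the scatter). Compound 4 is estimated at 2000 nM, with an expected range of 900 nM to 5000 nM.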

Compound 4, half-maximal inhibitory concentration: 3550 nM
The estimate for compound 4 lay 1.8-fold (0.25 log units) below the measured number; low and high end bracket the measured number.
By their numbers in this assay, from the lowest: compounds 2, 3 and 4 (each within the scatter of the next, the first and the last beyond it). At a limit, above all of these: compound 1.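

In this assay, among these compounds, a single methyl addition at this position again stays within the scatter, a 1.9-fold higher number from compound 3 to compound 4 (0.28 log units; within the scatter), but the two added carbons together give the first step beyond the scatter along the chain, a 2.6-fold higher number from compound 2 to compound 4 (0.41 log units; beyond the scatter), so ethyl to butyl is a modest but readable change. Butyl still keeps a large distance from the compound with hydrogen on this oxygen, an at least 28-fold lower number from compound 1 to compound 4 (1.44 log units; beyond the scatter). Compound 1 gives > 100000 nM, which is a limit and not a number: the limit of > 100000 nM in this assay, at which 1 of the 4 values shown sits.

On these data alone, whether pentyl or a longer chain raises the number further remains open. So does what a methyl ester, a branched chain such as isopropyl, or an amide would give at this position.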